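The source may hold more compounds than are shown below. What is called first, only, known or untested is meant among the compounds shown, and "the series" means these compounds.

In an assay on isolated protein for inhibition of Amine oxidase [flavin-containing] A (Homo sapiens), read by fluorescence and Amplex Red, with a stated time of 30 min, tested at 0.1 nM (a higher number here means a stronger effect of the compound at the concentration tested, a lower number a weaker effect), three compounds have been measured so far:
compound 1 `CCCCNc1nnc(SCC(=O)N(Cc2cccc([N+](=O)[O-])c2)c2ccc(F)cc2)s1`: 11.1%
compound 2 `CCCNc1nnc(SCC(=O)N(Cc2cccc([N+](=O)[O-])c2)c2ccc(F)cc2)s1`: 12%
compound 3 `CC(C)CNc1nnc(SCC(=O)N(Cc2cccc([N+](=O)[O-])c2)c2ccc(F)cc2)s1`: 12.6%

Compound 3 carries the highest of the three numbers, yet its nearest neighbour is compound 2, with a number 0.6 percentage points higher from compound 2 to compound 3 (within the scatter), and its furthest is compound 1, with a number 1.5 percentage points higher from compound 1 to compound 3 (within the scatter), both within the scatter, so the three stand level. Compound 4 `COCCNc1nnc(SCC(=O)N(Cc2cccc([N+](=O)[O-])c2)c2ccc(F)cc2)s1` has not yet been measured. It differs from compound 3 by methoxymethyl in place of isopropyl on a saturated chain carbon bound to a nitrogen on an aromatic ring. The measured steps of a number 0.9 percentage points higher from compound 1 to compound 2 (within the scatter), a number 1.5 percentage points higher from compound 1 to compound 3 (within the scatter) and a number 0.6 percentage points higher from compound 2 to compound 3 (within the scatter) all reshape the same chain without moving the number beyond the scatter, but none of them adds a hydrogen-bond acceptor, so they bear only loosely on this change. Compound 4 is therefore expected to stay near the others, with an estimated a number 0.6 percentage points lower from compound 3 to compound 4 (within the scatter). The estimate for compound 4 is 12%, within a range from 3% to 24%.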

Compound 4, a percentage reported as inhibition, at one concentration (the size of the read-out at that concentration, not a potency): 20.1%
For compound 4 the middle estimate is 8.1 percentage points below the measured one, and the stated range covers the measured number.
By their numbers in this assay, from the lowest: compounds 1, 2, 3 and 4 (each within the scatter of the next).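

In this assay, methoxymethyl in place of isopropyl on a saturated chain carbon bound to a nitrogen on an aromatic ring brings in a hydrogen-bond acceptor and gives a number 7.5 percentage points higher from compound 3 to compound 4 (within the scatter), while the other comparisons give a number 8.1 percentage points higher from compound 2 to compound 4 (within the scatter) and a number 9 percentage points higher from compound 1 to compound 4 (within the scatter). At this position, then, a chain carrying an oxygen stands level with the all-carbon chains. No evidence on the reason for these numbers is available. The compounds shown leave open whether a hydroxyl group, an amine or a longer chain carrying an oxygen at this position would move the number beyond the scatter.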